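Swapping the lactam ring in a weak alpha-1B binder

The source may hold more compounds than are shown below. What is called first, only, known or untested is meant among the compounds shown, and "the series" means these compounds.

Of the compounds shown here, three have been tested in an assay on COS cells for binding affinity to Alpha-1B adrenergic receptor (Homo sapiens); a lower number here means a stronger inhibitor, a higher number a weaker inhibitor. Compound 1 `CC(C)Oc1ccccc1N1CCN(CCN(C)C(=O)CN2CCCCC2=O)CC1` gives 10000 nM in this assay, and compound 2 `COc1ccccc1N1CCN(CCCNC(=O)CN2CCCCC2=O)CC1` gives 10000 nM as well. Compound 3 `CCOC(=O)C1CCC(=O)N1CC(=O)NCCN1CCN(c2ccccc2OC(C)C)CC1` gives 26300 nM, the highest of the three numbers; its gap to compound 1 and to compound 2 is the same and lies beyond the usual scatter, so compound 3 is the weakest binder among these three.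

Compound 4 `CC(C)Oc1ccccc1N1CCN(CCNC(=O)CN2CCCCCC2=O)CC1` has not yet been measured. It differs from compound 3 in one place: 2-oxoazepan-1-yl in place of 2-(ethoxycarbonyl)-5-oxopyrrolidin-1-yl on a saturated chain carbon bound to a carbonyl carbon. The rest of the molecule, including the shared core and the ethyl chain carrying the amide, stays as it is. For the measured compounds named here, the new lactam ring is close in kind to the one in compound 1, which sits at 10000 nM, and none of the three measured compounds reaches far below that level.

The step is therefore expected to be modest and downward, toward stronger binding, with a 2.6-fold lower number from compound 3 to compound 4 (0.42 log units; beyond the scatter) as the estimate. For compound 4 the expected value in this assay is 10000 nM, with a likely range from 3000 nM to 30000 nM.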

Compound 4, inhibition constant: 3540 nM
Estimate against measurement, compound 4: 2.8-fold (0.45 log units) above, within the range that was stated.
By their numbers in this assay, from the lowest: compound 4; then compounds 1 and 2 (each within the scatter of the next); then compound 3.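

In this assay, replacing 2-(ethoxycarbonyl)-5-oxopyrrolidin-1-yl with 2-oxoazepan-1-yl on a saturated chain carbon bound to a carbonyl carbon gives a 7.4-fold lower number from compound 3 to compound 4 (0.87 log units; beyond the scatter). For the compounds shown here, this is the first pair that differs in one place only, and it shows that the group at this place can shift the binding number beyond the usual scatter. The swap changes several things at once, as the ring goes from five-membered to seven-membered, the ethoxycarbonyl group disappears and the group loses heavy atoms, and no measurement here explains the step.

The compounds shown leave open whether the stronger binding follows the larger ring or the loss of the ethoxycarbonyl group; a plain 2-oxopyrrolidin-1-yl group, which keeps the five-membered ring without the ester, would separate the two. Also open, going by these compounds, is how a group carrying a carboxylic acid in place of the ethyl ester would compare with compound 4 at 3540 nM.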